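This account rests on a few compounds, and the source may have more. Where it says the series, first, only, none or still open, it means among the compounds named here.

Measured so far in a functional assay on A-375 cells (Homo sapiens) for antiproliferative activity, read by CCK-8 assay, with a stated time of 72 h, tested at 8 uM; on this read-out higher numbers stand for a stronger effect at the one concentration tested and lower numbers for a weaker effect:
compound 1 `Nc1ccccc1NC(=O)c1ccc(CSC(=S)N2CCN(c3ccc(Cl)cc3)CC2)cc1` gives 29%
compound 2 `N#Cc1ccc(N2CCN(C(=S)SCc3ccc(C(=O)Nc4ccccc4N)cc3)CC2)cc1` gives 62.9%
compound 3 `Nc1ccccc1NC(=O)c1ccc(CSC(=S)N2CCN(c3ncccn3)CC2)cc1` gives 67.9%

Compound 3 holds the highest of these three numbers. Its nearest neighbour is compound 2, and the gap between them, a number 5 percentage points higher from compound 2 to compound 3 (within the scatter), is within the usual scatter, so the two cannot be put in order. The gap to compound 1, a number 38.9 percentage points higher from compound 1 to compound 3 (beyond the scatter), is large and beyond the scatter.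

Compound 4 `Nc1ccccc1NC(=O)c1ccc(CSC(=S)N2CCN(c3ccncc3)CC2)cc1` differs from compound 3 in one place: pyridin-4-yl in place of pyrimidin-2-yl on an amine nitrogen in a ring. Among the compounds with values here, no measured step swaps one ring on this nitrogen for another in just this way. The steps that touch this position are a number 33.9 percentage points higher from compound 1 to compound 2 (beyond the scatter) and a number 38.9 percentage points higher from compound 1 to compound 3 (beyond the scatter); both are large, yet both start from the low number of compound 1, and the two higher groups land within the scatter of each other. The step to compound 4 is therefore expected to be small, a number 9.9 percentage points lower from compound 3 to compound 4 (within the scatter), with no clear direction beyond the scatter. Compound 4 is estimated at 58%, in a range of 38% to 75%.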

Compound 4, a percentage reported as inhibition, at one concentration (the size of the read-out at that concentration, not a potency): 90.7%
Compound 4: the middle estimate sits 32.7 percentage points below what was measured, outside the stated range (above it).
By their numbers in this assay, from the lowest: compound 1; then compounds 2 and 3 (each within the scatter of the next); then compound 4.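

Of the rings on this amine nitrogen, pyridin-4-yl stands apart from the other three, whereas the earlier data could not put pyrimidin-2-yl and 4-cyanophenyl in order: there is a number 22.8 percentage points higher from compound 3 to compound 4 (beyond the scatter), a number 27.8 percentage points higher from compound 2 to compound 4 (beyond the scatter) and a number 61.7 percentage points higher from compound 1 to compound 4 (beyond the scatter). The first of these steps shows that the choice between two six-membered aromatic rings of equal heavy-atom count still matters here, since going from 2 ring hetero atoms to 1 moves the number beyond the scatter. No measurement shown here explains this rise.

The compounds shown leave open how pyridin-3-yl or pyridin-2-yl would compare with pyridin-4-yl, which would test whether the place of the ring nitrogen counts. They also leave open whether any aromatic ring is needed at all, which a plain methyl or an acetyl on the same nitrogen could test.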